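Extending the acrylamide chain of compound 2 with a piperidine

The source may report more compounds than this note shows. Statements on the series, on what has been measured and on what is new or still open speak of the compounds shown alone.

Of the compounds shown here, three of a shared core have been measured in a functional assay on PC-3 cells (Homo sapiens) for antiproliferative activity, read by MTT assay, with a stated time of 72 h; on this read-out lower numbers stand for stronger inhibition and higher numbers for weaker inhibition. Compound 1 `CCC/C=C/C(=O)Nc1cc2c(N3CCc4ccccc43)ncnc2cc1OC` gives 4240 nM in this assay. Compound 2 `CCC/C=C/C(=O)Nc1cc2c(N3CCc4ccccc43)ncnc2cc1O[C@@H]1CCOC1` gives 9230 nM in this assay, and compound 3 `CCC/C=C/C(=O)Nc1cc2c(N3CCCc4ccccc43)ncnc2cc1O[C@@H]1CCOC1` gives 11800 nM in this assay. Compound 2 therefore sits second highest of the three numbers, close to compound 3 and further from compound 1.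

The two measured steps both touch the core. The first, a 2.2-fold higher number from compound 1 to compound 2 (0.34 log units; beyond the scatter), changes the ether group on the ring. The second, a 1.3-fold higher number from compound 2 to compound 3 (0.11 log units; within the scatter), changes the bicyclic amine on the core. Neither step touches the chain that carries the acrylamide, which is where compound 4 `O=C(/C=C/CN1CCC(CO)CC1)Nc1cc2c(N3CCc4ccccc43)ncnc2cc1O[C@@H]1CCOC1` differs from compound 2. The change there is 4-(hydroxymethyl)piperidin-1-yl in place of ethyl on a saturated chain carbon bound to a double-bonded chain carbon, so the chain gains a ring that carries a hydroxymethyl group.

Going by the values given here, because no measured step bears on this position, the direction of the step is open, and an expectation can only start from the value of compound 2 with a wide band. For compound 4 a number of 6000 nM is estimated in this assay, within a range from 1500 nM to 20000 nM, which means an expected step of a 1.5-fold lower number from compound 2 to compound 4 (0.19 log units; within the scatter) from compound 2.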

Compound 4, half-maximal inhibitory concentration: 3310 nM
For compound 4 the middle estimate is 1.8-fold (0.26 log units) above the measured one, within the range that was stated.
By their numbers in this assay, from the lowest: compounds 4 and 1 (each within the scatter of the next); then compounds 2 and 3 (each within the scatter of the next).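

Going by these compounds alone, compound 4 gives the first measured step at the chain position. In this assay, placing 4-(hydroxymethyl)piperidin-1-yl in place of ethyl on a saturated chain carbon bound to a double-bonded chain carbon gives a 2.8-fold lower number from compound 2 to compound 4 (0.45 log units; beyond the scatter), a modest change but one beyond the usual scatter. The earlier steps shown here changed only the ether group and the bicyclic amine on the shared core, whereas this one shows that the chain position can take a much larger group, with a ring, a nitrogen and a hydroxymethyl group, and that the number goes down rather than up. Nothing measured here explains this shift, and this single step cannot separate the part played by the ring from that of the hydroxymethyl group.

Still open, on these data alone, is whether a plain piperidin-1-yl, a morpholin-4-yl or a simple dimethylamino group on the same carbon would give a similar step, which would help show which part of the new group matters. As far as these compounds go, it is also open whether the same exchange would give a step of similar size on the methyl ether of compound 1 or with the 1,2,3,4-tetrahydroquinolin-1-yl group of compound 3.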